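This account rests on a few compounds, and the source may have more. Where it says the series, first, only, none or still open, it means among the compounds named here.

Of the compounds shown here, three have been measured so far. Compound 1 `O=C(O)COc1ccc(Cl)cc1C#Cc1ccc(CO)cc1F`, compound 2 `CC(C)Cc1ccncc1C#Cc1cc(Cl)ccc1OCC(=O)O` and compound 3 `Cc1ccc(S(=O)(=O)CC(C)C)cc1C#Cc1cc(Cl)ccc1OCC(=O)O` share the same core and differ in the ring joined to it through the alkyne. In an assay on CHO cells for displacement of a labelled ligand from prostaglandin D2 receptor 2 (Homo sapiens), read by scintillation counting (a lower number here means a stronger inhibitor, a higher number a weaker inhibitor), compound 1 gives 28 nM. In this assay compound 2 gives 4.9 nM, and in the same assay compound 3 gives 3 nM. Compound 2 stands second highest of these three numbers. Its nearest neighbour is compound 3, whose number lies within the usual scatter of its own, so the two cannot be told apart on this evidence; its furthest neighbour is compound 1, whose number is higher by more than the scatter.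

Compound 4 `O=C(O)COc1ccc(Cl)cc1C#Cc1cccnc1` has not yet been measured in this assay. It differs from compound 2 in a single place: hydrogen in place of isobutyl on an aromatic carbon. The isobutyl that leaves is a chain with no ring, carrying no donor and no acceptor, and the place it vacates sits on an aromatic carbon of a six-membered aromatic ring with 1 nitrogen. For the measured compounds named here, no pair of measured compounds isolates this change, so the expected step rests on a loose comparison only. The expectation is a moderate rise in the number in this assay, beyond the scatter, because compound 1, which also carries no isobutyl on its ring, gives 28 nM. Compound 4 is expected to give 40 nM, with a likely range from 12 nM to 150 nM. That estimate means an expected step of an 8.2-fold higher number from compound 2 to compound 4 (0.91 log units; beyond the scatter).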

Compound 4, inhibition constant: 117 nM
Compound 4: the middle estimate sits 2.9-fold (0.47 log units) below what was measured, within the range that was stated.
By their numbers in this assay, from the lowest: compounds 3 and 2 (each within the scatter of the next); then compound 1; then compound 4.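

Replacing the isobutyl with hydrogen on this aromatic carbon gives a 24-fold higher number from compound 2 to compound 4 (1.38 log units; beyond the scatter) in this assay, a large step towards a weaker inhibitor. For the compounds shown here, this is the first pair of measured compounds that differs in one place, so the size of this change now rests on a direct comparison rather than a loose one, and it shows that the group at this position, ortho to a large group and opposite the ring nitrogen, has a strong bearing on the number. Nothing measured here explains why the isobutyl goes with so much stronger an inhibitor than hydrogen does.

A single pair cannot show whether the whole isobutyl is needed, or whether a methyl, an ethyl, a cyclopropyl or a methoxy in the same place would keep some or all of the gain, and the same goes for a longer chain such as hexyl. It also leaves open whether swapping isobutyl for hydrogen would give a step of similar size on the other rings joined to the shared core through the alkyne.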